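A few compounds are considered here, and "the series" means these few. Any claim that something is new, unique, unknown or untested is made for them only; others in the source may bear on it.

Working notes on the series. In an ADME assay on HepG2 cells (Homo sapiens) for cytotoxicity, read by luminescence, CellTiter-Glo and ATP content, with a stated time of 72 h (on this read-out lower numbers stand for an effect already at smaller amounts and higher numbers for an effect only at larger amounts of compound), compound 1 `COc1ccc(F)cc1CNCCCNc1ccnc2cc(Oc3cccc(N(C)C)c3)ccc12`, which carries 3-(dimethylamino)phenoxy on the shared core, gives 3300 nM. For the measured compounds named here, compound 2 `COc1ccc(F)cc1CNCCCNc1ccnc2cc(CCC(C)C)ccc12`, with isopentyl on that aromatic carbon, gives 890 nM, the lower of the two numbers so far. Going by the values given here, the one measured step is a 3.7-fold lower number from compound 1 to compound 2 (0.57 log units; beyond the scatter), modest in size but beyond the scatter.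

Next in line is compound 3 `COc1ccc(F)cc1CNCCCNc1ccnc2cc(Oc3ccccc3)ccc12`, with phenoxy in place of isopentyl on an aromatic carbon. The entering group is the closest available match to the 3-(dimethylamino)phenoxy of compound 1, so the measured step bears on this change in reverse. A step of similar or somewhat smaller size towards a higher number is therefore expected in this assay. Among the compounds with values here, no measured compound carries phenoxy itself, and a single step gives little support, so a result within the scatter of compound 2 remains possible. The expected change is a 2.2-fold higher number from compound 2 to compound 3 (0.35 log units; beyond the scatter). For compound 3 the estimate is 2000 nM, with an expected range of 800 nM to 5000 nM.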

Compound 3, half-maximal effective concentration: 1500 nM
Beside the measured number, compound 3's estimate is 1.3-fold (0.12 log units) above it; the range from low to high includes it.
By their numbers in this assay, from the lowest: compounds 2 and 3 (each within the scatter of the next); then compound 1.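

In this assay, for the compounds shown here, the new result gives the first comparison of an open chain with an unsubstituted aromatic ring at this aromatic carbon: the step of a 1.7-fold higher number from compound 2 to compound 3 (0.23 log units; within the scatter) does not separate isopentyl from phenoxy. Going by these compounds alone, it also isolates the dimethylamino group on the phenoxy ring, since a 2.2-fold lower number from compound 1 to compound 3 (0.34 log units; beyond the scatter) replaces only that group with hydrogen and the step is modest but beyond the scatter. Among these three compounds, the higher number of compound 1 therefore goes with the dimethylamino group rather than with the phenoxy group as such, while no measurement at hand gives a reason for either step.

From the compounds shown here alone, it remains open whether this reading is specific to dimethylamino or would extend to other groups on the phenoxy ring, such as methoxy, a primary amine or a carboxylic acid. Going by these compounds, it also remains open whether a longer chain, or a saturated ring such as cyclohexyl, at the same aromatic carbon would stay within the scatter of compound 2 and compound 3.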